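Replacing the Amine Side Chain of Compound 1 with an Ester

The source may report more compounds than this note shows. Statements on the series, on what has been measured and on what is new or still open speak of the compounds shown alone.

Three compounds have been measured in a functional assay on PC-3 cells (Homo sapiens), read by MTT assay, with a stated time of 48 h; a lower number here means a stronger inhibitor, a higher number a weaker inhibitor:
Compound 1, `CCN(CC)CCNC(=O)c1ccc(C(CC)(CC)c2ccc(OCC(O)C(C)(C)C)c(C)c2)n1CC`, gives 220 nM.
Compound 2, `CCn1c(C(=O)NCCCN(C)C)ccc1C(CC)(CC)c1ccc(OCC(O)C(C)(C)C)c(C)c1`, gives 3100 nM.
Compound 3, `C=CCN(C)C(=O)c1ccc(C(CC)(CC)c2ccc(OCC(O)C(C)(C)C)c(C)c2)n1CC`, gives 25900 nM.

Compound 1 has the lowest number of the three and so is the strongest inhibitor here, since both of its steps to the others lie beyond the scatter. Compound 4, `CCn1c(C(=O)OCc2ccc(F)cc2)ccc1C(CC)(CC)c1ccc(OCC(O)C(C)(C)C)c(C)c1`, has not yet been measured. It differs from compound 1 in one place: (4-fluorobenzyl)oxy in place of (2-(diethylamino)ethyl)amino on a carbonyl carbon. Going by the values given here, two measured steps bear on this. Changing the amine-bearing chain gave a 14-fold higher number from compound 1 to compound 2 (1.15 log units; beyond the scatter), and removing it for a small amide substituent gave a 120-fold higher number from compound 1 to compound 3 (2.07 log units; beyond the scatter). Compound 4 also loses the amine-bearing chain, and the amide hydrogen with it, so a large rise in the number is expected. For compound 4 the estimated step is a 68-fold higher number from compound 1 to compound 4 (1.83 log units; beyond the scatter). The expected value for compound 4 is therefore 15000 nM, with a range from 3000 nM to 60000 nM.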

Compound 4, half-maximal inhibitory concentration: > 50000 nM
Compound 4: only a limit was reported; the forecaster's own chance of this, stated with the estimate: 15%; at least 3.3-fold (0.52 log units) between middle value and limit.
By their numbers in this assay, from the lowest: compound 1; then compound 2; then compound 3. At a limit, above all of these: compound 4.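

In this assay compound 4 gives > 50000 nM, which is a limit of the assay, not a number. Putting (4-fluorobenzyl)oxy on this carbonyl carbon, which makes an ester with a ring but no amine nitrogen, gives an at least 220-fold higher number from compound 1 to compound 4 (2.35 log units; beyond the scatter), and likewise an at least 16-fold higher number from compound 2 to compound 4 (1.20 log units; beyond the scatter), so the aromatic ring does not recover what was lost with the amine-bearing chains. Set against the small amide, the change gives an at least 1.9-fold higher number from compound 3 to compound 4 (0.28 log units; that floor lies within the scatter), so these two compounds cannot be put in order.

As far as these compounds go, it remains open whether the loss follows from the missing amine or from the ester linkage itself. A (4-fluorobenzyl)amino group or a 2-(diethylamino)ethoxy group on the same carbonyl carbon would separate these two changes.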